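Swapping a nitrile for a carbamoyl on a weak cytotoxic compound

The compounds below may be only part of what the source reports. "The series", "measured", "known", "first", "only" and "open" are said of these compounds alone.

Measured in a functional assay on KB cells (Homo sapiens) for cytotoxicity; a lower number here means a stronger inhibitor, a higher number a weaker inhibitor:
- compound 1 `N#Cc1cn([C@@H]2O[C@H](CO)[C@@H](O)[C@@H]2N=[N+]=[N-])c2ncnc(N)c12`: 151000 nM
- compound 2 `N#Cc1cn([C@@H]2O[C@H](CO)[C@@H](O)[C@@H]2N)c2ncnc(N)c12`: 105000 nM

Compound 1, at 151000 nM, cannot be told apart from compound 2, at 105000 nM, and both numbers are high. Compound 3 `[N-]=[N+]=N[C@H]1[C@H](O)[C@@H](CO)O[C@H]1n1cc(C(N)=O)c2c(N)ncnc21` keeps the core of compound 1 and changes one group, with carbamoyl in place of cyano on an aromatic carbon.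

Among the compounds with values here, only one measured step exists, a 1.4-fold lower number from compound 1 to compound 2 (0.16 log units; within the scatter). It swaps amino for azido on a saturated ring carbon, a different place, so it bears on this change only loosely. It shows that one change left this assay within the scatter. No measurement tests the cyano group itself, so no direction can be argued, and no step beyond the scatter is expected. The expected step is a 1.3-fold lower number from compound 1 to compound 3 (0.10 log units; within the scatter). For compound 3 the estimated value is 120000 nM, with an expected range of 30000 nM to 300000 nM.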

Compound 3, half-maximal inhibitory concentration: 179000 nM
Beside the measured number, compound 3's estimate is 1.5-fold (0.17 log units) below it, within the range that was stated.
By their numbers in this assay, from the lowest: compounds 2, 1 and 3 (each within the scatter of the next).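

Putting carbamoyl in place of cyano on this aromatic carbon gives, in this assay, a 1.2-fold higher number from compound 1 to compound 3 (0.07 log units; within the scatter), so compound 1 and compound 3 cannot be told apart. Within the data shown here, this is the first direct test of this position, and it shows that exchanging cyano for carbamoyl, which has one more heavy atom and a hydrogen-bond donor that cyano lacks, leaves the number high and within the scatter. No supporting measurement is available to explain this result.

The compounds shown leave open whether a different group on this carbon, such as a carboxylic acid or an aminomethyl group, would give a number that stands clear of the scatter. Going by these compounds, it also remains open how carbamoyl would read with amino in place of azido on the saturated ring carbon.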